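This account rests on a few compounds, and the source may have more. Where it says the series, first, only, none or still open, it means among the compounds named here.

Measured compounds:
- compound 1, `COc1cc(C)cc(-c2c(-c3ccnc(-c4ccc(C(C)=O)cc4)c3)cnn2CC#N)c1`, giving 85% in a functional assay on LOX IMVI cells (Homo sapiens) for cytotoxicity, read by sulforhodamine B assay, with a stated time of 48 h, tested at 100 nM; on this read-out higher numbers stand for a weaker effect at the one concentration tested and lower numbers for a stronger effect
- compound 2, `COc1cc(C)cc(-c2nn(CC#N)cc2-c2ccc(-c3cccc(C(C)=O)c3)nc2)c1`, giving 82%
- compound 3, `Cc1cc(O)cc(-c2nn(CC#N)cc2-c2ccnc(-c3ccc(N(C)C)cc3)c2)c1`, giving 101%

Among these three numbers compound 1 stands second highest. Its nearest neighbour is compound 2, a number within the usual scatter of it, so nothing can be said about the order of those two. Compound 3 lies furthest away, beyond the scatter, with the weaker effect of the three.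

Compound 4, `COc1cc(C)cc(-c2c(-c3ccnc(-c4ccc(N(C)C)cc4)c3)cnn2CC#N)c1`, is not yet measured. It differs from compound 1 in one place: dimethylamino in place of acetyl on an aromatic carbon. Compound 3 also carries a 4-(dimethylamino)phenyl group, but it differs from compound 1 in a second place too, so its number can only hint at the direction. On that hint, compound 4 is expected to give a weaker effect than compound 1, with the step from compound 1 to compound 4 estimated at a number 10 percentage points higher from compound 1 to compound 4 (within the scatter). The value of compound 4 is estimated at 95%, between 82% and 108%.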

Compound 4, a percentage reported as activity, at one concentration (the size of the read-out at that concentration, not a potency): 19%
The estimate for compound 4 lay 76 percentage points above the measured number; measured number outside the range, below it.
By their numbers in this assay, from the lowest: compound 4; then compounds 2 and 1 (each within the scatter of the next); then compound 3.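

In this assay, dimethylamino in place of acetyl gives a number 66 percentage points lower from compound 1 to compound 4 (beyond the scatter), a stronger effect. This is the first single change shown here to move the number beyond the usual scatter, so the group at this position matters greatly, although the two groups have the same count of heavy atoms. Nothing measured here explains the step.

The compounds shown leave open whether a primary amine, a methoxy group or a morpholine ring in this place would behave like dimethylamino or like acetyl. Among these compounds, with one concentration tested, they also give no potency for either compound.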